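Cyano to methyl on the benzyl ring of compound 2

The source may report more compounds than this note shows. Statements on the series, on what has been measured and on what is new or still open speak of the compounds shown alone.

Measured so far:
Compound 1, `N#Cc1ccccc1CSc1ncnc2c1ncn2[C@@H]1O[C@H](CO)[C@@H](O)[C@H]1O`, gives 38.9 nM in an assay on isolated protein for inhibition of Equilibrative nucleoside transporter 1 (Homo sapiens); on this read-out lower numbers stand for stronger inhibition and higher numbers for weaker inhibition.
Compound 2, `N#Cc1cccc(CSc2ncnc3c2ncn3[C@@H]2O[C@H](CO)[C@@H](O)[C@H]2O)c1`, gives 36.3 nM in this assay.

Going by the values given here, compound 2 has the lowest of the two numbers, but the only measured step, a 1.1-fold lower number from compound 1 to compound 2 (0.03 log units; within the scatter), keeps the two compounds within the scatter of each other, so no order between them can be read from these data.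

Compound 3, `Cc1cccc(CSc2ncnc3c2ncn3[C@@H]2O[C@H](CO)[C@@H](O)[C@H]2O)c1`, differs from compound 2 in one place: methyl in place of cyano on an aromatic carbon. Among the compounds with values here, the single measured step moves the cyano around the ring and does not remove it, so nothing in hand bears directly on replacing cyano by methyl. Within the data shown here, with no relevant step, the expectation for compound 3 in this assay is a number near that of compound 2, with a wide range, and the estimated step of a 1.5-fold higher number from compound 2 to compound 3 (0.18 log units; within the scatter) is not expected to exceed the scatter with any confidence. For compound 3 the estimate is 55 nM, ranging from 18 nM to 180 nM.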

Compound 3, inhibition constant: 16.2 nM
For compound 3 the middle estimate is 3.4-fold (0.53 log units) above the measured one; measured number outside the range, below it.
By their numbers in this assay, from the lowest: compound 3; then compounds 2 and 1 (each within the scatter of the next).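

In this assay, going by these compounds alone, the cyano group is not required at this aromatic carbon: the change from 3-cyanobenzyl to 3-methylbenzyl gives a 2.2-fold lower number from compound 2 to compound 3 (0.35 log units; beyond the scatter) and is the first step to exceed the scatter. The step of a 2.4-fold lower number from compound 1 to compound 3 (0.38 log units; beyond the scatter) points the same way, but it changes both the group and where it sits on the ring, so it does not isolate either change. No measurement shown here accounts for the difference between cyano and methyl.

From the compounds shown here alone, whether ethyl, chloro, methoxy or an amine on this same aromatic carbon would give a lower or higher number than methyl remains open. Also open, going by these compounds, is how methyl behaves on other carbons of the ring.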